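Working notes: 4-fluorophenyl to 3-fluorophenyl swap

The compounds below may be only part of what the source reports. "The series", "measured", "known", "first", "only" and "open" are said of these compounds alone.

Measured so far in an ADME assay on NIH3T3 cells (Mus musculus) for cytotoxicity, read by MTT assay, with a stated time of 96 h; a lower number here means a stronger inhibitor, a higher number a weaker inhibitor:
- compound 1 `Cc1cc(Cl)ccc1C(O)C1=CC(=O)c2ccccc2C1=O`: 7400 nM
- compound 2 `O=C1C=C(C(O)c2ccc(F)cc2)C(=O)c2ccccc21`: 11700 nM

Only these two compounds have numbers, and they do not form a step that differs in one place. Compound 2 at 11700 nM and compound 1 at 7400 nM lie within the scatter of each other, so no order between them can be claimed.

The next compound for this assay is compound 3 `O=C1C=C(C(O)c2cccc(F)c2)C(=O)c2ccccc21`, which has the same atoms as compound 2, joined differently: 3-fluorophenyl in place of 4-fluorophenyl on a saturated chain carbon bound to a double-bonded ring carbon and an oxygen on a saturated carbon. It carries 3-fluorophenyl in place of 4-fluorophenyl on a saturated chain carbon bound to a double-bonded ring carbon and an oxygen on a saturated carbon, and the shared core stays as it is.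

Among the compounds with values here, no measured pair shows this kind of change, so the data favour no direction. Within the data shown here, the only guide is that compound 1 at 7400 nM and compound 2 at 11700 nM sit close together despite their different aromatic groups. No change beyond the scatter is expected, and the estimated step is a 1.2-fold lower number from compound 2 to compound 3 (0.07 log units; within the scatter). For compound 3 the expected value is 10000 nM, with an estimated range from 5000 nM to 20000 nM.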

Compound 3, half-maximal inhibitory concentration: 82000 nM
Estimate against measurement, compound 3: 8.2-fold (0.91 log units) below, and the stated range ends below it.
By their numbers in this assay, from the lowest: compounds 1 and 2 (each within the scatter of the next); then compound 3.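

Working on the series in this assay, the swap of 4-fluorophenyl for 3-fluorophenyl on the saturated chain carbon gives a 7.0-fold higher number from compound 2 to compound 3 (0.85 log units; beyond the scatter) and supplies the first step that differs in one place. The leaving and entering groups have the same atoms and the same counts of rings, donors and acceptors, and the shared core stays as it is, so this position is sensitive to how the aromatic group is joined, even with no change in composition. The earlier compounds shown here could not show this, as their two values lay within the scatter and differed in more than one feature, but this is a single step between compound 2 and compound 3 and sets no general rule for the series. No measurement at hand gives a reason for this step.

The compounds shown do not tell whether 2-fluorophenyl or an unsubstituted phenyl at this position would stand closer to compound 2 or to compound 3. They also leave open how an amine or a carboxylic acid on the aromatic ring, or a longer chain in place of the saturated chain carbon, would read in this assay when set against compound 2.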